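Base replacement on a shared core: cytotoxicity working notes

The compounds below may be only part of what the source reports. "The series", "measured", "known", "first", "only" and "open" are said of these compounds alone.

Measured so far in a functional assay on MT4 cells (Homo sapiens) for cytotoxicity; a higher number here means that more compound is tolerated, a lower number that less compound is tolerated:
compound 1 `CNc1ncnc2c1ncn2[C@@H]1O[C@H](CO[Si](C)(C)C(C)(C)C)[C@@]2(OS(=O)(=O)C=C2N)[C@H]1O[Si](C)(C)C(C)(C)C` gives 14000 nM
compound 2 `CC(C)(C)[Si](C)(C)OC[C@H]1O[C@@H](n2c(=O)[nH]c(=O)c3[nH]cnc32)[C@H](O[Si](C)(C)C(C)(C)C)[C@]12OS(=O)(=O)C=C2N` gives 14000 nM

For the measured compounds named here, compound 2 stands level with compound 1 in this assay; the single measured step is no change at the digits printed from compound 1 to compound 2 (within the scatter). Compound 3 `CCn1cnc2ncn([C@@H]3O[C@H](CO[Si](C)(C)C(C)(C)C)[C@@]4(OS(=O)(=O)C=C4N)[C@H]3O[Si](C)(C)C(C)(C)C)c2c1=O` differs from compound 2 by a group of 12 heavy atoms (7 carbon, 4 nitrogen, 1 oxygen; one five-membered aromatic ring with 2 hetero atoms, one six-membered aromatic ring with 2 hetero atoms) in place of a group of 11 heavy atoms (5 carbon, 4 nitrogen, 2 oxygen; one five-membered aromatic ring with 2 hetero atoms, one six-membered aromatic ring with 2 hetero atoms), on a saturated ring carbon. Going by the values given here, the only comparable precedent is that step, which exchanged a group at the same saturated ring carbon and moved nothing in this assay. On that basis no step beyond the scatter is expected for compound 3, the expected step being no change at the digits printed from compound 2 to compound 3 (within the scatter). Compound 3 is therefore estimated at 14000 nM in this assay, with a range from 6000 nM to 30000 nM.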

Compound 3, half-maximal cytotoxic concentration: > 150000 nM
Compound 3 ended at the assay's limit; the forecaster's own chance of this, stated with the estimate: 10%; middle value at least 10-fold (1.02 log units) from the limit.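

In this assay, the group on this saturated ring carbon, next to the ring oxygen, can matter after all, which the level pair of compound 1 and compound 2 did not show. The entering group has 0 hydrogen-bond donors against 2 in the group it replaces, and the record shows an at least 10-fold higher number from compound 2 to compound 3 (1.02 log units; beyond the scatter), along with an at least 10-fold higher number from compound 1 to compound 3 (1.02 log units; beyond the scatter). The value of compound 3 is a limit, not a number: the limit of > 150000 nM in this assay, at which 1 of the 3 values shown sits.

A single compound cannot separate the added carbon from the missing donors as the feature that tracks this step. As far as these compounds go, whether a propyl chain or a primary amine at this place would give the same result remains open.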